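The source may hold more compounds than are shown below. What is called first, only, known or untested is meant among the compounds shown, and "the series" means these compounds.

Compound 1 `Cc1ccccc1-c1nn(Cc2ccc(F)cc2)cc1CNCCN1CCN(C)CC1` was tested in an ADME assay on Huh-7 cells (Homo sapiens) for cytotoxicity; on this read-out higher numbers stand for lower toxicity in this test and lower numbers for higher toxicity in this test. In this assay compound 1 gives > 20000 nM, which is a limit of the assay rather than a measured number. Compound 2 `CCN(CC)CCCNCc1cn(-c2ccc(F)cc2F)nc1-c1ccccc1C` was tested in the same assay. In this assay compound 2 gives > 20000 nM, again a limit of the assay and not a number. Compound 1 therefore stands at the limit of > 20000 nM in this assay, at which 2 of the 2 values shown sit, so no ranking among the measured compounds can be drawn from these values.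

Compound 3 `Cc1ccccc1-c1nn(-c2ccc(F)c(F)c2)cc1CNCCN1CCN(C)CC1` has not yet been measured in this assay. It differs from compound 1 by 3,4-difluorophenyl in place of 4-fluorobenzyl on an aromatic nitrogen. Within the data shown here, no step between measured compounds is available to guide the expectation, so no change beyond the usual scatter is expected for this assay. Compound 3 is therefore expected to give 25000 nM in this assay, within a range of 10000 nM to 60000 nM, and the expected step that the limit leaves unreadable from compound 1 to compound 3 is none beyond the scatter.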

Compound 3, half-maximal cytotoxic concentration: > 20000 nM
Compound 3 was reported as a limit; the forecaster's own chance of this, stated with the estimate: 75%; the middle value is on the limit's open side.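

In this assay compound 3 gives > 20000 nM, a limit of the assay and not a number. Among these compounds, compound 1 also stands at a limit, so no step from compound 1 to compound 3 can be read. The compounds shown leave open whether they differ at all in this read-out, as all of them share one limit: the limit of > 20000 nM in this assay, at which 3 of the 3 values shown sit.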